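A few compounds are considered here, and "the series" means these few. Any claim that something is new, unique, unknown or untested is made for them only; others in the source may bear on it.

Four compounds share a core built on a five-membered aromatic ring with 2 nitrogen that bears a cyano group; they differ in the group on an aromatic nitrogen of that ring and in a larger part of the molecule elsewhere. Compound 1 `COc1ccc(OC)c(/C=N/c2c(C#N)ncn2-c2ccc(F)cc2)c1` was tested in a functional assay on HT-29 cells (Homo sapiens) for antiproliferative activity, read by MTT assay, with a stated time of 48 h (on this read-out higher numbers stand for weaker inhibition and lower numbers for stronger inhibition), where compound 1 gives 16300 nM. Compound 3 `COc1ccc(OC)c(/C=N/c2c(C#N)ncn2Cc2ccc(F)cc2)c1` keeps everything else and changes one group: 4-fluorobenzyl in place of 4-fluorophenyl on an aromatic nitrogen. In this assay compound 3 gives 22400 nM, so the step of a 1.4-fold higher number from compound 1 to compound 3 (0.14 log units; within the scatter) is small. Compound 2 `N#Cc1ncn(-c2ccc(F)cc2)c1/N=C/c1ccc([N+](=O)[O-])cc1` differs from compound 1 in more than one place; the difference between the two cores is not broken down here. In this assay compound 2 gives 15900 nM, a value within the scatter of compound 1, so no order between them can be read.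

Compound 4 `N#Cc1ncn(Cc2ccc(F)cc2)c1/N=C/c1ccc([N+](=O)[O-])cc1` has not yet been measured. It relates to compound 2 as compound 3 relates to compound 1: 4-fluorobenzyl in place of 4-fluorophenyl on an aromatic nitrogen. The place of the change is described in the same words for both pairs, so this is the same change made on a different core. Because the earlier step of a 1.4-fold higher number from compound 1 to compound 3 (0.14 log units; within the scatter) stayed within the scatter, a step of similar size is expected here: a 1.3-fold higher number from compound 2 to compound 4 (0.12 log units; within the scatter). Compound 4 is therefore estimated to give 21000 nM in this assay, with an expected range from 9000 nM to 50000 nM. Going by these compounds, this expectation rests on a single measured pair, and anything wider remains unknown.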

Compound 4, half-maximal inhibitory concentration: 5720 nM
Compound 4: middle estimate off by 3.7-fold (0.56 log units), on the high side; the whole stated range lies above it.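

In this assay, the swap of 4-fluorophenyl for 4-fluorobenzyl on the aromatic nitrogen gives a 2.8-fold lower number from compound 2 to compound 4 (0.44 log units; beyond the scatter), a modest gain in inhibition on the core of compound 2. Set beside the earlier step, this shows that the same change does not carry over unchanged from one core to the other: the same change on two cores in this assay, a 1.4-fold higher number (0.14 log units; within the scatter) from compound 1 to compound 3 and a 2.8-fold lower number (0.44 log units; beyond the scatter) from compound 2 to compound 4, 3.8-fold (0.58 log units) apart, beyond the scatter of two such steps. What the change does in this series therefore depends on the rest of the molecule, but the two pairs do not show why: the cores differ in more than one place, so no single part of them can be held responsible, and two pairs give no rule for predicting the change on a further core.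

The compounds shown leave open which feature of the larger part decides the outcome, for instance whether an amine or a carboxylic acid in place of the nitro group would behave like compound 4 or like compound 3. They also leave open whether a longer chain on the same nitrogen, such as 4-fluorophenethyl, would extend the gain seen on the core of compound 2, and whether any of this holds in other cell lines.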